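The source may report more compounds than this note shows. Statements on the series, on what has been measured and on what is new or still open speak of the compounds shown alone.

Measured so far:
- compound 1, `CCCCC[Se]c1nc([Se]CCCCC)c2cccnc2n1`: > 100000 nM in a functional assay on HT-29 cells (Homo sapiens) for cytotoxicity, read by MTT assay, with a stated time of 72 h; on this read-out higher numbers stand for weaker inhibition of growth and lower numbers for stronger inhibition of growth
- compound 2, `Sc1nc(NCc2ccccc2)c2ccccc2n1`: 63500 nM in this assay

Compound 1 stands at the limit of > 100000 nM in this assay, at which 1 of the 2 values shown sits, so for it only a limit and no number is known. Among the measured compounds shown here, compound 2 gives a number in this assay, but no step between the two is drawn. The change to compound 3, `CCCCC[Se]c1nc(N)c2cccnc2n1`, is one nitrogen atom in place of a group of 6 heavy atoms (5 carbon, 1 selenium; no ring), on an aromatic carbon. For the measured compounds named here, with no measured step to lean on, the step in this assay is expected to stay small, within the scatter. Compound 3 is therefore estimated at 90000 nM, between 20000 nM and 300000 nM, a step of an at least 1.1-fold lower number from compound 1 to compound 3 (0.04 log units; that floor lies within the scatter) that is itself only an expectation.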

Compound 3, concentration for total growth inhibition: 20000 nM
Beside the measured number, compound 3's estimate is 4.5-fold (0.65 log units) above it; the measured number falls inside the stated range.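

Among the compounds shown here, at this aromatic carbon, next to the ring nitrogen, amino in place of the group of 6 heavy atoms (5 carbon, 1 selenium) gives the first readable change in this assay: an at least 5.0-fold lower number from compound 1 to compound 3 (0.69 log units; beyond the scatter). Growth inhibition at a measurable level therefore does not need that selenium-bearing group at this position. Compound 1 stands at a limit of the assay, so the step is only a floor: the limit of > 100000 nM in this assay, at which 1 of the 3 values shown sits.

The compounds shown leave open whether a methylamine, a hydroxyl or a shorter selenium-bearing chain at this carbon would match amino. They also leave open what the remaining group of 6 heavy atoms on compound 3 contributes.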